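This account rests on a few compounds, and the source may have more. Where it says the series, first, only, none or still open, it means among the compounds named here.

Three compounds of a shared core were examined in an ADME assay on MDCK cells (Canis lupus familiaris) for cytotoxicity, read by microscopy, with a stated time of 6 days; on this read-out lower numbers stand for higher toxicity in this test and higher numbers for lower toxicity in this test. Compound 1 `CCCCCCCCNc1nccnc1C(=O)NCc1ccccc1` gives 100000 nM there, and compound 3 `CCCCCCNc1cncc(C(=O)NCc2ccccc2)n1` gives 20000 nM. For compound 2 `CCCCCCNc1cnc(C(=O)NCc2ccccc2)cn1` the reading in this assay is only a limit of the test, > 100000 nM, so its true position is not known beyond that boundary; this is the situation described by the limit of > 100000 nM in this assay, at which 1 of the 3 values shown sits. Compound 2 therefore stands at the least toxic end of what the numbers show, while compound 3 sits at a lower concentration than compound 1.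

The next compound, compound 4 `CCCCCCCCNc1cnc(C(=O)NCc2ccccc2)cn1`, differs from compound 2 in one place: ethyl in place of hydrogen on a saturated chain carbon, six bonds along the chain from a nitrogen on an aromatic ring. Among the measured compounds shown here, since no pair of measured compounds differs only in this way, the size of the step cannot be read from the data. The expectation is that compound 2 and compound 4 are separated by a step of a number no higher from compound 2 to compound 4 (the limit leaves the size open) in this assay, within the usual scatter or at most slightly toward higher toxicity. Compound 4 is accordingly estimated at 100000 nM in this assay, with a range from 30000 nM to 300000 nM.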

Compound 4, minimum cytotoxic concentration: >= 20000 nM
Compound 4: only a limit was reported; the forecaster's own chance of this, stated with the estimate: 50%; the middle value lies beyond the limit too.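

Among the compounds shown here, compound 2 and compound 4 are both reported only as limits, so no step between them can be read in this assay. The compounds shown leave open where either compound truly stands, and whether ethyl in place of hydrogen changes the reading at all.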